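Chalcone notes: from 2,6-dichlorophenyl to 2,6-difluorophenyl

A few compounds are considered here, and "the series" means these few. Any claim that something is new, unique, unknown or untested is made for them only; others in the source may bear on it.

- compound 1 (`COc1cccc(/C=C/C(=O)c2c(OC)cc(OC)cc2OC)c1`): 1800 nM
- compound 2 (`COc1cc(OC)c(C(=O)/C=C/c2c(Cl)cccc2Cl)c(OC)c1`): 1090 nM

Both values come from a functional assay for inhibition, with Homo sapiens as the target (a higher number here means a weaker inhibitor, a lower number a stronger inhibitor), and they lie within the scatter of each other, so the numbers do not separate compound 2 from compound 1. Compound 3 (`COc1cc(OC)c(C(=O)/C=C/c2c(F)cccc2F)c(OC)c1`) has not yet been measured. It carries 2,6-difluorophenyl in place of 2,6-dichlorophenyl on a double-bonded chain carbon bound to a double-bonded chain carbon, and the difference counts as 2,6-difluorophenyl in place of 2,6-dichlorophenyl on a double-bonded chain carbon bound to a double-bonded chain carbon in full.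

Among the compounds with values here, only one measured step bears on this place. It is a 1.7-fold lower number from compound 1 to compound 2 (0.22 log units; within the scatter) and it exchanged 3-methoxyphenyl for 2,6-dichlorophenyl. Within the data shown here, that step stayed within the scatter, so the one exchange seen here at this place moved the number little. Among the measured compounds shown here, no measured step exchanges chlorine for fluorine, so this support is indirect and the range is kept wide.

No step beyond the scatter is expected in this assay for this change. The expected step is a 1.2-fold higher number from compound 2 to compound 3 (0.08 log units; within the scatter) in this series. The estimated value for compound 3 is 1300 nM in this assay. The expected range for compound 3 runs from 600 nM to 2800 nM on the same read-out.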

Compound 3, half-maximal inhibitory concentration: 1290 nM
For compound 3 the middle estimate is 1.0-fold (0.00 log units) above the measured one, and the stated range covers the measured number.
By their numbers in this assay, from the lowest: compounds 2, 3 and 1 (each within the scatter of the next).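

In this assay, exchanging chlorine for fluorine on this ring gives a 1.2-fold higher number from compound 2 to compound 3 (0.07 log units; within the scatter), so this read-out does not separate 2,6-difluorophenyl from 2,6-dichlorophenyl on a double-bonded chain carbon bound to a double-bonded chain carbon. The exchange from 3-methoxyphenyl now has a second reading, a 1.4-fold lower number from compound 1 to compound 3 (0.14 log units; within the scatter), and all three groups seen at this place therefore stand within the scatter of one another on the shared core. No supporting data are available to interpret these small steps.

The compounds shown leave open whether a group of another kind at this place, such as a phenyl ring carrying an amine or a carboxylic acid, would give a step beyond the scatter. They also leave open whether changes elsewhere on the shared core would move the number in this assay more than the exchanges at this place have.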